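Replacing a Butyl Chain with 4-Pentylphenyl on the Alkyne

The source may report more compounds than this note shows. Statements on the series, on what has been measured and on what is new or still open speak of the compounds shown alone.

The pair of measured compounds share a core and differ at the chain on the triple bond and in the geometry of the linker. Compound 1 `CCCCC#Cc1cn(C/C=C\CN2C(=O)c3ccccc3C2=O)c(=O)[nH]c1=O` has a butyl group there, and in a functional assay on HepG2 cells (Homo sapiens) for antiproliferative activity, read by MTT assay, with a stated time of 3 days (a higher number here means a weaker inhibitor, a lower number a stronger inhibitor), compound 1 gives 17000 nM, the highest of the two numbers. Compound 2 `CCCCCCC#Cc1cn(C/C=C/CN2C(=O)c3ccccc3C2=O)c(=O)[nH]c1=O` carries a hexyl chain, and in this assay compound 2 gives 14000 nM; the two values lie within the scatter of each other, so neither compound can be called the stronger inhibitor. Compound 3 `CCCCCc1ccc(C#Cc2cn(C/C=C\CN3C(=O)c4ccccc4C3=O)c(=O)[nH]c2=O)cc1` is not yet measured. It differs from compound 1 as follows: 4-pentylphenyl in place of butyl on a triple-bonded carbon. Going by the values given here, no step between measured compounds informs this change, so only a modest expectation can be formed. The step of a 2.1-fold lower number from compound 1 to compound 3 (0.33 log units; beyond the scatter) is expected to lean toward a lower number, just beyond the scatter. Compound 3 is therefore estimated at 8000 nM, within a range from 2000 nM to 30000 nM.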

Compound 3, half-maximal inhibitory concentration: 18000 nM
For compound 3 the middle estimate is 2.3-fold (0.35 log units) below the measured one; the range from low to high includes it.
By their numbers in this assay, from the lowest: compounds 2, 1 and 3 (each within the scatter of the next).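

In this assay, replacing butyl with 4-pentylphenyl on a triple-bonded carbon gives a 1.1-fold higher number from compound 1 to compound 3 (0.02 log units; within the scatter), and this is the first comparison shown that changes this position alone. The two numbers cannot be told apart, so a group with a six-membered aromatic ring of carbon only can stand here in place of the open chain without the number moving beyond the scatter. Nothing available explains this result.

From the compounds shown here alone, whether an amine or a carboxylic acid in place of butyl on the triple-bonded carbon would move the number beyond the scatter remains open. The part played by the geometry of the linker also remains open, as no two compounds shown differ in that place alone.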